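The source may report more compounds than this note shows. Statements on the series, on what has been measured and on what is new or still open speak of the compounds shown alone.

Measured compounds:
- compound 1 `COCC#Cc1cn([C@H]2C[C@H](O)[C@@H](CO)O2)c(=O)[nH]c1=O`: 254 ug/mL
- compound 2 `CCCC/C=C\c1cn([C@H]2C[C@H](O)[C@@H](CO)O2)c(=O)[nH]c1=O`: 361 ug/mL
- compound 3 `O=c1[nH]c(=O)n([C@H]2C[C@H](O)[C@@H](CO)O2)cc1C#CCCO`: > 1000 ug/mL (a limit of the assay)

In a functional assay on L1210 cells (Mus musculus) (a lower number here means a stronger inhibitor, a higher number a weaker inhibitor), compound 2 gives the highest of the two numbers that are actual values. Its nearest neighbour is compound 1, and the step of a 1.4-fold higher number from compound 1 to compound 2 (0.15 log units; within the scatter) lies within the scatter. Compound 3 reaches only the limit of this assay (the limit of > 1000 ug/mL in this assay, at which 1 of the 3 values shown sits).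

Compound 4 `CC#Cc1cn([C@H]2C[C@H](O)[C@@H](CO)O2)c(=O)[nH]c1=O` differs from compound 2 in one place: prop-1-yn-1-yl in place of hex-1-en-1-yl on an aromatic carbon. The entering group is a short triple-bonded chain with no hydrogen-bond donors or acceptors, like the chain of compound 1 without its methoxy.

Within the data shown here, three measured steps bear on this. The exchange of an alkynyl for an alkenyl chain, a 1.4-fold higher number from compound 1 to compound 2 (0.15 log units; within the scatter), changed little. Adding a hydroxymethyl in place of methoxy, an at least 3.9-fold higher number from compound 1 to compound 3 (0.59 log units; beyond the scatter), and moving from hex-1-en-1-yl to 4-hydroxybut-1-yn-1-yl, an at least 2.7-fold higher number from compound 2 to compound 3 (0.44 log units; beyond the scatter), both gave higher numbers, and compound 4 carries no such hydroxymethyl. The expected step of a 1.4-fold lower number from compound 2 to compound 4 (0.14 log units; within the scatter) is therefore small, at most a modest move toward a lower number, within the scatter. Compound 4 is estimated at 260 ug/mL, between 120 ug/mL and 600 ug/mL.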

Compound 4, concentration for 50% inhibition: 164 ug/mL
Beside the measured number, compound 4's estimate is 1.6-fold (0.20 log units) above it; low and high end bracket the measured number.
By their numbers in this assay, from the lowest: compounds 4, 1 and 2 (each within the scatter of the next, the first and the last beyond it). At a limit, above all of these: compound 3.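

In this assay, among these compounds, the step of a 2.2-fold lower number from compound 2 to compound 4 (0.34 log units; beyond the scatter) shows that prop-1-yn-1-yl in place of hex-1-en-1-yl on this aromatic carbon can lower the number beyond the scatter, whereas the earlier steps beyond the scatter all went toward a higher number. On the saturated chain carbon bound to the triple-bonded carbon, hydrogen in place of methoxy stays within the scatter, a 1.5-fold lower number from compound 1 to compound 4 (0.19 log units; within the scatter), while hydrogen in place of hydroxymethyl at that carbon gives an at least 6.0-fold lower number from compound 3 to compound 4 (0.78 log units; beyond the scatter). That last step is only a bound, as compound 3 stands at a limit and not at a number: the limit of > 1000 ug/mL in this assay, at which 1 of the 4 values shown sits.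

Chain length and bond type change together in the step from hex-1-en-1-yl to prop-1-yn-1-yl, so the compounds shown do not separate the two, and a hex-1-yn-1-yl or a prop-1-en-1-yl chain at this position would be needed to do so. As far as these compounds go, how an amine or a carboxylic acid at the end of the short triple-bonded chain would read in this assay also stays open.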